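A few compounds are considered here, and "the series" means these few. Any claim that something is new, unique, unknown or untested is made for them only; others in the source may bear on it.

Series notes. Among the compounds with values here, compound 3 `COc1cc(C)cc(-c2nn(CC#N)cc2-c2ccnc(-c3ccc(N(C)C)cc3)c2)c1` gives -15% in a functional assay on COLO 205 cells (Homo sapiens) for cytotoxicity, read by sulforhodamine B assay, with a stated time of 48 h, tested at 100 nM (on this read-out higher numbers stand for a weaker effect at the one concentration tested and lower numbers for a stronger effect), the lowest of the three numbers measured so far. Compound 1 `COc1cc(C)cc(-c2nn(CC#N)cc2-c2ccc(-c3cccc(C(C)=O)c3)nc2)c1` gives 88% in this assay, and compound 2 `Cc1cc(O)cc(-c2nn(CC#N)cc2-c2ccnc(-c3ccc(Oc4ccccc4)cc3)c2)c1` gives 99%; both stand far above compound 3, beyond the scatter, while the gap between compound 1 and compound 2 lies within it. Compound 4 `Cc1cc(O)cc(-c2nn(CC#N)cc2-c2ccnc(-c3ccc(N(C)C)cc3)c2)c1` is not yet measured. It differs from compound 3 in one place only: hydrogen in place of methyl on an oxygen on an aromatic ring. Within the data shown here, no measured pair in the set isolates this change; compound 2 carries the hydroxy form and compound 1 the methoxy form, but those two also differ from each other and from compound 3 in the rest of the structure, so their values do not speak to this step on their own. The working expectation is that the step from compound 3 to compound 4 in this assay is small, not beyond the scatter, estimated as a number 20 percentage points higher from compound 3 to compound 4 (beyond the scatter). Compound 4 is accordingly expected to give about 5% in this assay, within a range of -20% to 55%, the upper end left wide since nothing measured here tests the change directly.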

Compound 4, a percentage reported as activity, at one concentration (the size of the read-out at that concentration, not a potency): 94%
The estimate for compound 4 lay 89 percentage points below the measured number; the whole stated range lies below it.
By their numbers in this assay, from the lowest: compound 3; then compounds 1, 4 and 2 (each within the scatter of the next, the first and the last beyond it).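

In this assay, within the data shown here, the first isolated reading of this change, hydrogen in place of methyl on an oxygen on an aromatic ring, is a number 109 percentage points higher from compound 3 to compound 4 (beyond the scatter) and shows that the strong effect of compound 3 does not survive methoxy to hydroxy on this ring when the dimethylamino group is held fixed. With the hydroxy form held instead, dimethylamino in place of phenoxy on an aromatic carbon gives a number 5 percentage points lower from compound 2 to compound 4 (within the scatter) so in this pair the exchange of that group does not register, and the dimethylamino group alone does not carry the effect. The methoxy form is no sufficient condition either, since compound 1 also carries it and gives 88% in a structure that differs from compound 3 in more than one place, so that value is no direct test of this step.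

Nothing available here accounts for the size of this step.

Open, as far as these compounds go, is whether an ethoxy group or an amine on this ring in place of the methoxy keeps the effect of compound 3, and whether methoxy with phenoxy in place of dimethylamino would do the same.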